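A few compounds are considered here, and "the series" means these few. Any claim that something is new, unique, unknown or untested is made for them only; others in the source may bear on it.

In a functional assay on HT-29 cells (Homo sapiens) for inhibition, read by MTT assay, with a stated time of 2 days (a higher number here means a weaker inhibitor, a lower number a stronger inhibitor), compound 1 (`Nc1cccc(/C=C/c2ccccc2)c1`) gives 12.9 ug/mL and compound 2 (`Oc1ccc(/C=C/c2cccc(O)c2)cc1`) gives 6.9 ug/mL with the two values inside the usual scatter of each other. Compound 3 (`Nc1cccc(/C=C/c2ccc(O)cc2)c1`) carries amino in place of hydroxy on an aromatic carbon of compound 2 (amino in place of hydroxy on an aromatic carbon). For the measured compounds named here, no measured pair shows this exchange on its own. Compound 1 also carries amino and gives 12.9 ug/mL within the scatter of compound 2, so no large change is expected, and the estimated step (a 1.2-fold lower number from compound 2 to compound 3 (0.06 log units; within the scatter)) should stay within the scatter. Compound 3 is expected near 6 ug/mL with an estimated range from 2 ug/mL to 15 ug/mL in this assay.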

Compound 3, half-maximal inhibitory concentration: 51 ug/mL
For compound 3 the middle estimate is 8.5-fold (0.93 log units) below the measured one; the measured number lies above the stated range.
By their numbers in this assay, from the lowest: compounds 2 and 1 (each within the scatter of the next); then compound 3.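

In this assay, amino in place of hydroxy on an aromatic carbon, meta to a group of 9 heavy atoms, is not a neutral exchange: it gives a 7.4-fold higher number from compound 2 to compound 3 (0.87 log units; beyond the scatter). Hydroxy in place of hydrogen on an aromatic carbon also weakens the amino compound, with a 4.0-fold higher number from compound 1 to compound 3 (0.60 log units; beyond the scatter), so with amino at this position the added hydroxy brings no gain. Nothing measured here accounts for either step.

As far as these compounds go, whether a methoxy group or a carboxylic acid at this position would hold the number of compound 2 stays open. So does whether the loss belongs to amino alone or to amino together with the hydroxy of compound 3.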